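A Swap of the Aryl Group on the Fused Core

A few compounds are considered here, and "the series" means these few. Any claim that something is new, unique, unknown or untested is made for them only; others in the source may bear on it.

Of the compounds shown here, three have been measured in a functional assay on HCT-116 cells (Homo sapiens) for inhibition, read by sulforhodamine B assay, with a stated time of 72 h; on this read-out higher numbers stand for weaker inhibition and lower numbers for stronger inhibition. Compound 1 `COc1ccc2cc(C(C)c3nnc4n3N=C(c3ccc(Br)cc3)CS4)ccc2c1` gives 11700 nM. Compound 2 `CC(C)Cc1ccc(C(C)c2nnc3n2N=C(c2ccc(Cl)cc2)CS3)cc1` gives 6700 nM. Compound 3 `CC(c1ccc(-c2ccccc2)c(F)c1)c1nnc2n1N=C(c1ccc(Cl)cc1Cl)CS2` gives 6900 nM, a number that lies between those of compound 2 and compound 1, and both of those gaps fall within the scatter of this assay. Compound 4 `Cc1ccc(C2=Nn3c(nnc3C(C)c3ccc(-c4ccccc4)c(F)c3)SC2)cc1` has not been measured; it differs from compound 3 by 4-methylphenyl in place of 2,4-dichlorophenyl on a carbon with a double bond to nitrogen. For the measured compounds named here, no measured pair shows this change, so the step of a 1.2-fold higher number from compound 3 to compound 4 (0.06 log units; within the scatter) is expected to stay within the scatter, in no particular direction. Compound 4 is estimated at 8000 nM, with a range from 3000 nM to 25000 nM.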

Compound 4, half-maximal inhibitory concentration: 4800 nM
Compound 4: middle estimate off by 1.7-fold (0.22 log units), on the high side; the range from low to high includes it.
By their numbers in this assay, from the lowest: compounds 4, 2, 3 and 1 (each within the scatter of the next, the first and the last beyond it).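

In this assay, 4-methylphenyl in place of 2,4-dichlorophenyl on the carbon with a double bond to nitrogen gives a 1.4-fold lower number from compound 3 to compound 4 (0.16 log units; within the scatter). This first single-place pair shows that, with the rest of compound 3 held fixed, exchanging this dichlorinated ring for the methylated one leaves the number within the scatter. Nothing measured here explains the result. Going by these compounds, it remains open whether an amine or a carboxylic acid on this phenyl ring would give a step beyond the scatter. On these data alone, the same exchange also remains untested alongside the other groups carried by compound 1 and compound 2.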